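A few compounds are considered here, and "the series" means these few. Any claim that something is new, unique, unknown or untested is made for them only; others in the source may bear on it.

Measured in an ADME assay on the whole organism (strain Sprague-Dawley) with Rattus norvegicus as the target, at a dose of 0.5 mg/kg by the intravenous route; a lower number here means that the compound disappears faster, a higher number that the compound lasts longer:

compound 1 `CC(C)(C)C#Cc1cc(N(C(=O)[C@H]2CC[C@H](C)CC2)[C@H]2CC[C@](O)(CO[C@H]3CCOC3)CC2)c(C(=O)O)s1`: 3.8 h
compound 2 `CC(C)(C)C#Cc1cc(N(C(=O)[C@H]2CC[C@H](C)CC2)[C@H]2CC[C@@H](Oc3ccc(=O)[nH]n3)CC2)c(C(=O)O)s1`: 0.5 h
compound 3 `CC(C)(C)C#Cc1cc(N(C(=O)[C@H]2CC[C@H](C)CC2)[C@H]2CC[C@@H](Oc3cccnc3)CC2)c(C(=O)O)s1`: 0.2 h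

Compound 2 holds the middle place among these three numbers. Compound 3 lies below it. Compound 1 gives 3.8 h in this series, a much higher number than that of compound 2.

The unmeasured compound 4 `CC(C)(C)C#Cc1cc(N(C(=O)[C@H]2CC[C@H](C)CC2)[C@H]2CC[C@H](Oc3ccc(=O)[nH]n3)CC2)c(C(=O)O)s1` is a stereoisomer of compound 2, and the comparison reads: the two compounds have the same atoms and bonds and differ only in configuration as drawn: 2 of 4 stereo elements differ; a stereocentre at a saturated ring carbon is drawn s in compound 2 and r in compound 4; a stereocentre at a saturated ring carbon is drawn s in compound 2 and r in compound 4.

Among the compounds with values here, no measured pair here differs in configuration alone, so the data offer no direct precedent for this change. Within the data shown here, the one measured step, a 2.5-fold lower number from compound 2 to compound 3 (0.40 log units; beyond the scatter), exchanges the aromatic ring on an oxygen on a saturated carbon and bears on the question only as a rough gauge of how far this series can move. No step beyond the scatter is therefore expected, and neither direction is favoured. In this assay the estimated step is no change at the digits printed from compound 2 to compound 4 (within the scatter) and it is held loosely. For compound 4 the estimate is 0.5 h, with an expected range from 0.2 h to 1.2 h.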

Compound 4, mean residence time: 1.6 h
Compound 4: middle estimate off by 3.2-fold (0.51 log units), on the low side; the whole stated range lies below it.
By their numbers in this assay, from the lowest: compound 3; then compound 2; then compound 4; then compound 1.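

Within the data shown here, compounds 2 and 4 form the first measured pair here in which configuration alone changes, and in this assay this gives a 3.2-fold higher number from compound 2 to compound 4 (0.51 log units; beyond the scatter). At this ring, the number therefore responds to the arrangement at the two saturated ring carbons as well as to the exchange of the aromatic ring on the oxygen, which gave a 2.5-fold lower number from compound 2 to compound 3 (0.40 log units; beyond the scatter). The step can be placed on configuration and on nothing else, because no other difference separates the pair: the fact that compounds 2 and 4 differ only in the configuration as drawn

From the compounds shown here alone, it remains open whether the same change of configuration would act in the same direction with the ring of compound 3, or with an amine or a methyl group in place of the aromatic ring on the oxygen. Compound 4 differs from compound 1 in more than one place, so the number of compound 1, 3.8 h, cannot be traced to any single change.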